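Naphthamide piperazines: the arylpiperazine substituent and binding

A few compounds are considered here, and "the series" means these few. Any claim that something is new, unique, unknown or untested is made for them only; others in the source may bear on it.

Measured so far:
compound 1 `O=C(NCCCCN1CCN(c2cccc3[nH]c(=O)[nH]c23)CC1)c1ccc2ccccc2c1` — 158 nM
compound 2 `O=C(NCCCCN1CCN(c2cccc(Cl)c2)CC1)c1ccc2ccccc2c1` — 50.2 nM
compound 3 `CCOC(=O)Nc1cccc(N2CCN(CCCCNC(=O)c3ccc4ccccc4c3)CC2)c1` — 1030 nM

In an assay on isolated protein for displacement of a labelled ligand from Alpha-1A adrenergic receptor (Homo sapiens) (a higher number here means a weaker inhibitor, a lower number a stronger inhibitor), compound 3 gives the highest number of the three: a 3.1-fold lower number from compound 1 to compound 2 (0.50 log units; beyond the scatter) and a 21-fold higher number from compound 2 to compound 3 (1.31 log units; beyond the scatter). Compound 3 thus stands furthest from compound 2 and nearer to compound 1, though still well apart from both.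

Compound 4 `O=C(NCCCCN1CCN(c2cccc(C(F)(F)F)c2)CC1)c1ccc2ccccc2c1` keeps the shared core and alters only the arylpiperazine substituent: trifluoromethyl in place of (ethoxycarbonyl)amino on an aromatic carbon. The entering group carries no hydrogen-bond donor and no acceptor, in contrast to the leaving group with its one donor and two acceptors.

The step that bears most directly on this change is a 21-fold higher number from compound 2 to compound 3 (1.31 log units; beyond the scatter), where a small halogen on the same aromatic carbon gave the low number and the (ethoxycarbonyl)amino group the high one. Compound 4 returns to a small, donor-free substituent at that position, so a large step downward in this assay is expected, roughly reversing that earlier loss, though without a measured trifluoromethyl analogue the size is uncertain. Compound 4 is expected to come in at about 80 nM (range 25 nM to 250 nM), an estimated step of a 13-fold lower number from compound 3 to compound 4 (1.11 log units; beyond the scatter).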

Compound 4, inhibition constant: 283 nM
For compound 4 the middle estimate is 3.5-fold (0.55 log units) below the measured one, outside the stated range (above it).
By their numbers in this assay, from the lowest: compound 2; then compounds 1 and 4 (each within the scatter of the next); then compound 3.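

In this assay, trifluoromethyl on this aromatic carbon recovers only part of the loss seen with (ethoxycarbonyl)amino (a 3.6-fold lower number from compound 3 to compound 4 (0.56 log units; beyond the scatter)), and it remains clearly behind chloro (a 5.6-fold higher number from compound 2 to compound 4 (0.75 log units; beyond the scatter)). Losing the hydrogen-bond donor and acceptors of (ethoxycarbonyl)amino is therefore not enough on its own to reach the value of compound 2. Compound 4 also cannot be told apart from compound 1, despite the change of the whole aryl group on the piperazine nitrogen (a 1.8-fold higher number from compound 1 to compound 4 (0.25 log units; within the scatter)).

No data shown here account for the separation of chloro and trifluoromethyl at this position. From the compounds shown here alone, whether fluoro, methyl, methoxy or an amine on the same carbon would sit nearer compound 2 or compound 4 remains open.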